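The source may hold more compounds than are shown below. What is called first, only, known or untested is meant among the compounds shown, and "the series" means these compounds.

Measured so far in a functional assay on HeLa cells (Homo sapiens) for antiproliferative activity, read by MTT assay, with a stated time of 24 h; on this read-out higher numbers stand for weaker inhibition and lower numbers for stronger inhibition:
compound 1 `Brc1ccc(Cc2nnc(Cn3nnc4ccccc43)o2)cc1`: 198000 nM
compound 2 `COc1ccc(Cc2nnc(Cn3nnc4ccccc43)o2)cc1`: 150000 nM

Within the data shown here, compound 1 has no distinct place on these numbers, since only one other compound has been measured and the two values lie within the scatter of each other. The next compound to read is compound 3 `COc1ccccc1Cc1nnc(Cn2nnc3ccccc32)o1`, which keeps the core of compound 1. The change is 2-methoxyphenyl in place of 4-bromophenyl on a saturated chain carbon bound to an aromatic carbon.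

Among the measured compounds shown here, one measured step bears on this, a 1.3-fold lower number from compound 1 to compound 2 (0.12 log units; within the scatter), where methoxy takes the place of bromo on an aromatic carbon. That step stays within the scatter. For the measured compounds named here, it is only a partial guide, as no measured compound carries 2-methoxyphenyl, so the effect of that placement is unknown. With this single small step as the precedent, no shift beyond the scatter is expected in this assay. The estimated step is a 1.3-fold lower number from compound 1 to compound 3 (0.12 log units; within the scatter). For compound 3 the expected value is 150000 nM, with an estimated range of 70000 nM to 300000 nM.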

Compound 3, half-maximal inhibitory concentration: 11000 nM
Beside the measured number, compound 3's estimate is 14-fold (1.13 log units) above it; the measured number lies below the stated range.
By their numbers in this assay, from the lowest: compound 3; then compounds 2 and 1 (each within the scatter of the next).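

In this assay, the position on the saturated chain carbon bound to an aromatic carbon proves sensitive to which substituted phenyl it carries: 2-methoxyphenyl in place of 4-methoxyphenyl gives a large step (a 14-fold lower number from compound 2 to compound 3 (1.13 log units; beyond the scatter)), although the earlier exchange of bromo for methoxy on the aromatic carbon stayed within the scatter (a 1.3-fold lower number from compound 1 to compound 2 (0.12 log units; within the scatter)). The step from the 4-bromophenyl compound is likewise large (an 18-fold lower number from compound 1 to compound 3 (1.26 log units; beyond the scatter)), so compound 3 stands apart from both earlier compounds, and among these three compounds a methoxy group alone does not account for the lower number, since compound 2 carries one too. Nothing available on these compounds gives a reason for the step.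

On these data alone, whether the lower number of compound 3 survives an ethoxy group or an amine in place of its methoxy remains open, as does what 2-bromophenyl would give at the same position. Also open, as far as these compounds go, is whether the same step appears on a longer chain in place of the saturated chain carbon, or in cell lines other than HeLa.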